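From bromo to benzyloxycarbonyl on a shared core

The source may report more compounds than this note shows. Statements on the series, on what has been measured and on what is new or still open speak of the compounds shown alone.

compound 1 `Fc1ccc2[nH]c(-c3cn(-c4ccccc4)nc3-c3ccc(Cl)cc3)nc2c1`: 2770 nM
compound 2 `Clc1ccc(-c2nn(-c3ccccc3)cc2-c2nc3cc(Cl)ccc3[nH]2)cc1`: 1630 nM
compound 3 `Clc1ccc(-c2nn(-c3ccccc3)cc2-c2nc3cc(Br)ccc3[nH]2)cc1`: 2160 nM

All three compounds were tested in a functional assay on HeLa cells (Homo sapiens) for antiproliferative activity, read by MTT assay, with a stated time of 48 h (a lower number here means a stronger inhibitor, a higher number a weaker inhibitor), and differ only in one halogen on the shared core. In this test compound 3 gives 2160 nM and cannot be separated from compound 1 or compound 2 on these numbers. The two steps that reach it are small: a 1.3-fold lower number from compound 1 to compound 3 (0.11 log units; within the scatter) and a 1.3-fold higher number from compound 2 to compound 3 (0.12 log units; within the scatter) are the whole of its standing. The remaining halogen exchange is a 1.7-fold lower number from compound 1 to compound 2 (0.23 log units; within the scatter) and it is no larger in any meaningful sense.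

The next compound, compound 4 `O=C(OCc1ccccc1)c1ccc2[nH]c(-c3cn(-c4ccccc4)nc3-c3ccc(Cl)cc3)nc2c1`, carries benzyloxycarbonyl in place of bromo on an aromatic carbon of a six-membered aromatic ring of carbon only benzyloxycarbonyl in place of bromo on an aromatic carbon and keeps the rest of the structure. The three measured steps bear on this position, but each only exchanges one halogen for another. Within the data shown here, no measured compound carries a group of this kind, so they give only a weak guide. With no measured step beyond the scatter, none is expected here either, though with wide uncertainty in this assay and in either direction. The estimated change is a 1.2-fold lower number from compound 3 to compound 4 (0.08 log units; within the scatter) and it rests on that reasoning alone. For compound 4 the expected value is 1800 nM with an estimated range from 500 nM to 7000 nM as its likely span.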

Compound 4, half-maximal inhibitory concentration: 8130 nM
Compound 4: middle estimate off by 4.5-fold (0.65 log units), on the low side, and the stated range ends below it.
By their numbers in this assay, from the lowest: compounds 2, 3 and 1 (each within the scatter of the next); then compound 4.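

In this assay, among these compounds, the three halogens at this aromatic carbon of the shared core had stayed within the scatter of one another, and benzyloxycarbonyl gives the first steps beyond it: against bromo the change is a 3.8-fold higher number from compound 3 to compound 4 (0.58 log units; beyond the scatter) and against chloro it is a 5.0-fold higher number from compound 2 to compound 4 (0.70 log units; beyond the scatter) while against fluoro it is a 2.9-fold higher number from compound 1 to compound 4 (0.47 log units; beyond the scatter) on these numbers. All three steps run the same way, so this position, which looked indifferent while only one halogen was exchanged for another, does respond to what is placed on it, and this exchange brings in a second six-membered aromatic ring and a carbonyl. Nothing measured here accounts for this change in the number.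

A carboxylic acid, a methyl ester or an amide on the same carbon would show whether the higher number goes with the carbonyl or with the added benzyl ring. Going by these compounds, it also remains open whether a small group that is not a halogen, such as methoxy or nitrile, would stay with the halogens or move towards compound 4.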